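A few compounds are considered here, and "the series" means these few. Any claim that something is new, unique, unknown or untested is made for them only; others in the source may bear on it.

Compound 1 `CC(C)[C@@H](NC(=O)CCc1ccc(F)cc1)C(=O)N1CCC(c2ccc(Cl)cc2)CC1`: 70 nM
Compound 2 `CC[C@@H](C)[C@@H](NC(=O)c1ccccc1)C(=O)N1CCC(c2ccc(Cl)cc2)CC1`: 45 nM
Compound 3 `Cc1ccccc1C(=O)NC(CC(C)C)C(=O)N1CCC(c2ccc(Cl)cc2)CC1`: 88 nM

These three compounds were tested in an assay on THP-1 cells for displacement of a labelled ligand from C-C chemokine receptor type 1 (Homo sapiens); on this read-out lower numbers stand for stronger inhibition and higher numbers for weaker inhibition. On that read-out compound 1 gives 70 nM, the second highest of the three numbers; its gap to compound 3 and its gap to compound 2 both fall within the usual scatter of repeated measurements, so none of the three can be told apart from the others. Compound 4 `Cc1ccccc1CCC(=O)N[C@@H](C(=O)N1CCC(c2ccc(Cl)cc2)CC1)C(C)C` has not yet been measured. It differs from compound 1 in one place: 2-methylphenyl in place of 4-fluorophenyl on a saturated chain carbon, two bonds along the chain from a carbonyl carbon. Among the measured compounds shown here, no pair of measured compounds shows this change, so no measured step guides the expectation. With all three measured values sitting close together, compound 4 is expected to land near them, and the expected step of a 1.3-fold higher number from compound 1 to compound 4 (0.11 log units; within the scatter) is no larger than the scatter. The estimate for compound 4 is 90 nM, with a range from 40 nM to 200 nM.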

Compound 4, half-maximal inhibitory concentration: 19 nM
Compound 4: the middle estimate sits 4.7-fold (0.68 log units) above what was measured; the whole stated range lies above it.
By their numbers in this assay, from the lowest: compound 4; then compounds 2, 1 and 3 (each within the scatter of the next).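

In this assay, 2-methylphenyl in place of 4-fluorophenyl gives a 3.7-fold lower number from compound 1 to compound 4 (0.57 log units; beyond the scatter) at this saturated chain carbon. The change is small in size, with the same count of heavy atoms on each side, yet it moves the number beyond the scatter, which the three earlier compounds could not show, as no two of them differed in one place. Nothing available here explains this difference.

On these data alone, the step removes the fluorine and adds the methyl together, so the contribution of each stays open. Plain phenyl or 2-fluorophenyl on the same chain would help to separate them.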